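Swapping a Side Chain on an Acid Without a Benzyl Ester

A few compounds are considered here, and "the series" means these few. Any claim that something is new, unique, unknown or untested is made for them only; others in the source may bear on it.

Compound 1, `C[C@@H](O)[C@H](NC(=O)CN(c1nc(Cl)nc2[nH]cnc12)C1CC1)C(=O)OCc1ccccc1`, was tested in a functional assay on the whole organism (Tail, strain ICR) with Mus musculus as the target, in the tail flick test, with a stated time of 90 min, at a dose of 25 umol/kg by the oral route (a lower number here means a weaker effect, a higher number a stronger effect of the compound at the dose given), where compound 1 gives 29.9%. Two compounds measured alongside it each differ from compound 1 in one place. Compound 2, `NCCCC[C@H](NC(=O)CN(c1nc(Cl)nc2[nH]cnc12)C1CC1)C(=O)OCc1ccccc1`, carries 4-aminobutyl in place of 1-hydroxyethyl on a saturated chain carbon bound to an amide-type nitrogen and a carbonyl carbon and in this assay compound 2 gives 35.3%, the step being a number 5.4 percentage points higher from compound 1 to compound 2 (within the scatter). Compound 3, `C[C@@H](O)[C@H](NC(=O)CN(c1nc(Cl)nc2[nH]cnc12)C1CC1)C(=O)O`, instead has hydrogen in place of benzyl on an oxygen next to a carbonyl group, and in this assay compound 3 gives 35.9%, the step being a number 6 percentage points higher from compound 1 to compound 3 (within the scatter). All three readings sit close together, so none of them can be called clearly apart from the others.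

Compound 4, `NCCCC[C@H](NC(=O)CN(c1nc(Cl)nc2[nH]cnc12)C1CC1)C(=O)O`, has not yet been measured. It differs from compound 3 by 4-aminobutyl in place of 1-hydroxyethyl on a saturated chain carbon bound to an amide-type nitrogen and a carbonyl carbon. This is the same change that turns compound 1 into compound 2, made at the same place on the chain, and it appears twice among these four compounds. The two cores on which it is made differ in hydrogen in place of benzyl on an oxygen next to a carbonyl group.

For compound 4 the expected step in this assay is a number 4.1 percentage points higher from compound 3 to compound 4 (within the scatter), resting on the earlier step of a number 5.4 percentage points higher from compound 1 to compound 2 (within the scatter), which was itself within the scatter, so a similarly small shift is expected here. Compound 4 is therefore estimated to give 40% in this assay, with an expected range from 28% to 52%.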

Compound 4, a percentage reported as activity, at one dose (the size of the read-out at that dose, not a potency): 28.8%
Compound 4: middle estimate off by 11.2 percentage points, on the high side, within the range that was stated.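

In this assay, putting 4-aminobutyl in place of 1-hydroxyethyl gives a number 7.1 percentage points lower from compound 3 to compound 4 (within the scatter) on the core of compound 3, and this step does not stand apart from the same change made on the core of compound 1: the same change on two cores in this assay, a number 5.4 percentage points higher (within the scatter) from compound 1 to compound 2 and a number 7.1 percentage points lower (within the scatter) from compound 3 to compound 4, 12.5 percentage points apart, within the scatter of two such steps. The second change in this set of four compounds reads the same way, with hydrogen in place of benzyl on an oxygen next to a carbonyl group giving a number 6.5 percentage points lower from compound 2 to compound 4 (within the scatter) and no clear difference from the earlier step: the same change on two cores in this assay, a number 6 percentage points higher (within the scatter) from compound 1 to compound 3 and a number 6.5 percentage points lower (within the scatter) from compound 2 to compound 4, 12.5 percentage points apart, within the scatter of two such steps. The result therefore gives no sign that the core alters what the side-chain change does, but it does not show that the change carries over with a fixed size or direction, as every step here lies within the scatter and each reading comes from a single dose.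

The compounds shown leave open whether a different group on this saturated chain carbon, such as a carboxylic acid on the side chain or a longer chain, would move the reading clear of the scatter. They also leave open whether a methyl ester or an amide in place of the benzyl ester would do so.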